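A few compounds are considered here, and "the series" means these few. Any claim that something is new, unique, unknown or untested is made for them only; others in the source may bear on it.

Compound 1 `c1ccc(-c2cncc(OC[C@@H]3CCN3)c2)cc1` gives 0.046 nM in an assay on brain for binding affinity to Neuronal acetylcholine receptor; alpha4/beta2 (Rattus norvegicus), read by radioligand binding; a higher number here means a weaker inhibitor, a lower number a stronger inhibitor.
Compound 2 `Cc1ncccc1OC[C@@H]1CCN1` gives 1.36 nM in this assay.
Compound 3 `Clc1ncc(OC[C@@H]2CCN2)cc1-c1ccccc1` gives 0.022 nM in this assay.

Compound 2 shows the highest number of the three. How its core differs from the core of compound 1 is not broken down here. Compound 3 arises from compound 1 by chloro in place of hydrogen on an aromatic carbon, and that step gave a 2.1-fold lower number from compound 1 to compound 3 (0.32 log units; beyond the scatter). Compound 4 `Cc1nc(Cl)ccc1OC[C@@H]1CCN1`, not yet measured, arises from compound 2 by chloro in place of hydrogen on an aromatic carbon. This is the same kind of change, though its surroundings differ: in compound 3 the chloro sits ortho to a phenyl group and para to a (azetidin-2-yl)methoxy group, whereas in compound 4 it sits meta to a methyl group and para to a group of 6 heavy atoms. Resting on the modest step of a 2.1-fold lower number from compound 1 to compound 3 (0.32 log units; beyond the scatter), a step of similar size is expected here: a 2.1-fold lower number from compound 2 to compound 4 (0.32 log units; beyond the scatter). Compound 4 is therefore estimated at 0.65 nM in this assay, with a likely range from 0.3 nM to 1.5 nM.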

Compound 4, inhibition constant: 2.4 nM
Compound 4: the middle estimate sits 3.7-fold (0.57 log units) below what was measured, outside the stated range (above it).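

On the core of compound 2, chloro in place of hydrogen on an aromatic carbon gave a 1.8-fold higher number from compound 2 to compound 4 (0.25 log units; within the scatter), so no real change can be claimed for this step in this assay. The gain seen on the core of compound 1 therefore did not carry over, and the two steps do differ: the same change on two cores in this assay, a 2.1-fold lower number (0.32 log units; beyond the scatter) from compound 1 to compound 3 and a 1.8-fold higher number (0.25 log units; within the scatter) from compound 2 to compound 4, 3.7-fold (0.57 log units) apart, beyond the scatter of two such steps. Within the data shown here, this shows that the effect of this change depends on the core it is made on, but with only one pair per core it does not show which difference between the cores matters, or why.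

On these data alone, it remains open whether a fluoro, a methoxy or an amine in place of the chloro, next to the ring nitrogen, would shift the number on the core of compound 2. As far as these compounds go, it is also open how the chloro step would behave on a third core.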